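Ethoxy to butoxy on the core of compound 1

A few compounds are considered here, and "the series" means these few. Any claim that something is new, unique, unknown or untested is made for them only; others in the source may bear on it.

Among the measured compounds shown here, in a functional assay on P388 cells (Mus musculus) for cytotoxicity (on this read-out higher numbers stand for an effect only at larger amounts of compound and lower numbers for an effect already at smaller amounts), compound 1 (`CCOc1cc(-c2ccccc2)nc2ccccc12`) gives 6 ug/mL and is the only compound with an actual number. Compound 2 (`COCOc1ccc(-c2cc(=O)c3ccccc3n2C)cc1`) reads > 10 ug/mL and this is a limit of the assay, not a number.

Compound 3 (`CCCCOc1cc(-c2ccccc2)nc2ccccc12`) differs from compound 1 by ethyl in place of hydrogen on a saturated chain carbon, two bonds along the chain from an oxygen on an aromatic ring in the change from ethoxy to butoxy. For the measured compounds named here, no measured pair shows what such a change does, so the expectation rests on compound 1 at 6 ug/mL alone. An estimated 1.2-fold lower number from compound 1 to compound 3 (0.08 log units; within the scatter) stays within the usual scatter, with neither direction favoured. Compound 3 is expected at 5 ug/mL in this assay with an estimated range of 2 ug/mL to 10 ug/mL for the coming reading.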

Compound 3, half-maximal effective concentration: > 10 ug/mL
Compound 3: only a limit was reported (the forecaster's own chance of this, stated with the estimate: 15%); middle value at least 2.0-fold (0.30 log units) away from the limit.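

Ethoxy to butoxy gives the first reading on this chain position in this assay, with an at least 1.6-fold higher number from compound 1 to compound 3 (0.22 log units; that floor lies within the scatter) as the step. Compound 3 reads > 10 ug/mL, and this is a limit of the assay, not a number. Lengthening the chain therefore gives no second number to set beside compound 1, and the step cannot be shown to exceed the scatter, since the reading stops at the same ceiling as most of the series: the limit of > 10 ug/mL in this assay, at which 2 of the 3 values shown sit.

Going by these compounds, how far compound 3 really lies from compound 1 remains open. Also open, on these data alone, is whether methoxy or propoxy on the shared core gives a number rather than a limit, and whether a chain carrying an amine does the same.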